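The source may report more compounds than this note shows. Statements on the series, on what has been measured and on what is new or still open speak of the compounds shown alone.

Measured compounds in a physicochemical assay for lipophilicity, measured as octanol-water partition; on this read-out lower numbers stand for lower lipophilicity and higher numbers for higher lipophilicity:
- compound 1 `O=C(NNc1ccnc2cc(Cl)ccc12)c1ccccc1/N=C/c1ccccc1Cl`: 5.5
- compound 2 `O=C(NNc1ccnc2cc(Cl)ccc12)c1ccccc1/N=C/c1cccc(Cl)c1Cl`: 6.1
- compound 3 `O=C(NNc1ccnc2cc(Cl)ccc12)c1ccccc1/N=C/C=C/c1ccccc1`: 5.54

Compound 2 stands highest of the three in this assay: a number 0.60 log units higher from compound 1 to compound 2 (beyond the scatter) and a number 0.56 log units lower from compound 2 to compound 3 (beyond the scatter), both beyond the scatter, while a number 0.04 log units higher from compound 1 to compound 3 (within the scatter) lies within it.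

Compound 4 `O=C(NNc1ccnc2cc(Cl)ccc12)c1ccccc1/N=C/c1cc2ccccc2[nH]c1=O` is not yet measured. Relative to compound 2 the change is a group of 11 heavy atoms (9 carbon, 1 nitrogen, 1 oxygen; one six-membered aromatic ring of carbon only, one six-membered aromatic ring with 1 hetero atom) in place of a group of 8 heavy atoms (6 carbon, 2 chlorine; one six-membered aromatic ring of carbon only), on a carbon with a double bond to nitrogen. Going by the values given here, the only step that bears on it is a number 0.60 log units higher from compound 1 to compound 2 (beyond the scatter); here two chlorines leave at once, and no measured step covers a group carrying a hydrogen-bond donor and acceptor in that place. A step downward beyond the scatter is therefore expected, larger than the single-chloro step. Compound 4 is expected at 4.4, within 3.6 to 5.2, which means an estimated a number 1.70 log units lower from compound 2 to compound 4 (beyond the scatter).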

Compound 4, partition coefficient: 4.65
Estimate against measurement, compound 4: 0.25 log units below, within the range that was stated.
By their numbers in this assay, from the lowest: compound 4; then compounds 1 and 3 (each within the scatter of the next); then compound 2.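

At the carbon with a double bond to nitrogen, this assay now spans a much wider range than the earlier groups gave: a number 1.45 log units lower from compound 2 to compound 4 (beyond the scatter) and a number 0.89 log units lower from compound 3 to compound 4 (beyond the scatter) and a number 0.85 log units lower from compound 1 to compound 4 (beyond the scatter) together place compound 4 lowest of the four. Going by these compounds alone, this is the first group in that place with a hydrogen-bond donor and acceptor, and the step from the dichlorophenyl compound is the largest. Nothing measured gives a cause for this drop.

The compounds shown do not separate the hydrogen-bond donor and acceptor from the added ring. From the compounds shown here alone, how an amine or a carboxylic acid in this place would read also stays open.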